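Replacing 3-methylbut-2-en-1-yl with benzyl on the shared core

The source may hold more compounds than are shown below. What is called first, only, known or untested is meant among the compounds shown, and "the series" means these compounds.

Within the data shown here, in a functional assay on J774.A1 cells (Mus musculus) for inhibition, read by Griess assay, with stated times of 1 h and 24 h (a higher number here means a weaker inhibitor, a lower number a stronger inhibitor), compound 2 `CC(C)=CCOc1ccccc1C1CC(=O)c2ccccc2O1` gives 34300 nM and compound 1 `O=C1CC(c2ccccc2OCc2ccc(F)cc2)Oc2ccccc21` gives 25500 nM as the only other value, so the two lie within the scatter of each other and neither can be ranked. Compound 3 `O=C1CC(c2ccccc2OCc2ccccc2)Oc2ccccc21` has not yet been measured in this assay. Its difference from compound 2 is phenyl in place of 2-methylprop-1-en-1-yl on a saturated chain carbon bound to an oxygen on an aromatic ring, with phenyl in place of 2-methylprop-1-en-1-yl on a saturated chain carbon bound to an oxygen on an aromatic ring. Among the measured compounds shown here, only one measured step bears on this place. It is a 1.3-fold higher number from compound 1 to compound 2 (0.13 log units; within the scatter), where 2-methylprop-1-en-1-yl stands in place of 4-fluorophenyl. That exchange of an aromatic group for the same departing group of the present change stayed within the scatter, so no step beyond the scatter is expected here, although a single step is thin evidence. The expected change is a 1.2-fold lower number from compound 2 to compound 3 (0.09 log units; within the scatter) and remains within the scatter. For compound 3 the estimated value is 28000 nM, within an expected range from 14000 nM to 55000 nM.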

Compound 3, half-maximal inhibitory concentration: 23200 nM
The estimate for compound 3 lay 1.2-fold (0.08 log units) above the measured number, within the range that was stated.
By their numbers in this assay, from the lowest: compounds 3, 1 and 2 (each within the scatter of the next).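

In this assay the exchange of 3-methylbut-2-en-1-yl for benzyl can now be read directly, and the step is a 1.5-fold lower number from compound 2 to compound 3 (0.17 log units; within the scatter). At this place, on a saturated chain carbon bound to an oxygen on an aromatic ring, a chain with a double bond and a phenyl group therefore cannot be told apart, just as the earlier pair could not be separated with 4-fluorophenyl in the same place. Among these compounds, the new compound also gives a first reading of the fluoro group itself, with hydrogen in place of fluoro on an aromatic carbon, and the step of a 1.1-fold lower number from compound 1 to compound 3 (0.04 log units; within the scatter) shows that this exchange cannot be told apart from no change either.

The three compounds leave open whether a different kind of group at this place, such as an amine, a carboxylic acid or a longer chain, would move the number beyond the scatter, and whether a group such as nitrile or trifluoromethyl in place of the fluoro would do so. No evidence is at hand that bears on why these numbers lie so close together.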